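The compounds below may be only part of what the source reports. "The series", "measured", "known", "first", "only" and "open" are said of these compounds alone.

Compounds with a result so far:

- compound 1, `Cc1ccc(-c2nn(-c3ccccc3)cc2-c2nnc(-c3ccccc3)o2)cc1`: "not determined" (no result reported)
- compound 2, `O=[N+]([O-])c1ccc(-c2nn(-c3ccccc3)cc2-c2nnc(-c3ccccc3)o2)cc1`: 74.3 mg/kg
- compound 3, `Cc1ccc(-c2nn(-c3ccccc3)cc2-c2nnc(-c3ccc(Cl)cc3)o2)cc1`: "not determined" (no result reported)

The assay is a functional assay on the whole organism for inhibition, with Rattus norvegicus as the target, read by paw edema, with stated times of 1 h and 2 h; on this read-out higher numbers stand for an effect only at larger amounts of compound and lower numbers for an effect already at smaller amounts. Of the three compounds, only compound 2 carries a number; in this assay compound 2 gives 74.3 mg/kg. Compound 3 stands without a single number, and compound 1 is a further entry without one, so nothing shows how compound 3 compares with compound 2 or with compound 1.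

Compound 4, `Clc1ccc(-c2nnc(-c3cn(-c4ccccc4)nc3-c3ccc(Cl)cc3)o2)cc1`, differs from compound 3 in one place: chloro in place of methyl on an aromatic carbon. Within the data shown here, no step between two measured compounds is available to show what this exchange does in this assay, and compound 3 itself has no number to step from. Among the measured compounds shown here, the only anchor is the single value of compound 2, a close relative sharing the same core. On that basis the result for compound 4 is expected to fall near that value, with a wide range in either direction, since the exchange of methyl for chloro could shift it up or down without any measured example to say which. Compound 4 is estimated at 70 mg/kg, in the range 25 mg/kg to 200 mg/kg.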

Compound 4, dose for half-maximal effect: 199 mg/kg
Beside the measured number, compound 4's estimate is 2.8-fold (0.45 log units) below it; low and high end bracket the measured number.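

Compound 3 has no single number in this assay, so no step can be read from compound 3 to compound 4. The compounds shown leave open what the change from 4-methylphenyl to 4-chlorophenyl does to the dose. Nothing shown here bears on the result for compound 4.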